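Swapping a pyridine chain for hydroxy on a sulfonyl sulfur

The source may hold more compounds than are shown below. What is called first, only, known or untested is meant among the compounds shown, and "the series" means these compounds.

Compound 1 `CCC(CC)O[C@@H]1C=C(S(=O)(=O)CCc2ccncc2)C[C@H](N)[C@H]1NC(C)=O` offers no number to start from: in an ADME assay on MDCK cells (Canis lupus familiaris) for cytotoxicity, with a stated time of 48 h (a lower number here means that less compound is tolerated, a higher number that more compound is tolerated), compound 1 is recorded as "not determined" (no result reported). The nearest guides are two relatives with changes elsewhere on the shared core. Compound 2 `CCC(CC)O[C@@H]1C=C(S(=O)(=O)CCc2ccncc2)C[C@H](NC(=N)N)[C@H]1NC(C)=O` gives > 100000 nM, which is a limit of the assay and not a number. Compound 3 `CCC(CC)O[C@@H]1C=C(S(C)(=O)=O)C[C@H](NC(=N)N)[C@H]1NC(C)=O` also gives a limit, > 100000 nM. All the measured evidence therefore comes down to the limit of > 100000 nM in this assay, at which 2 of the 3 values shown sit.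

Compound 4 `CCC(CC)O[C@@H]1C=C(S(=O)(=O)O)C[C@H](N)[C@H]1NC(C)=O` has hydroxy in place of 2-(pyridin-4-yl)ethyl on a sulfonyl sulfur of compound 1: hydroxy in place of 2-(pyridin-4-yl)ethyl on a sulfonyl sulfur. Within the data shown here, one measured step bears on this, as it also removes the pyridine ring from the sulfonyl group: a step that the two limits leave unreadable from compound 2 to compound 3. Both of its ends are limits, so its size cannot be read, and neither compound carries the hydroxy. Resting on a step that the two limits leave unreadable from compound 2 to compound 3, no step beyond the scatter is expected in this assay, in either direction. For compound 4 the estimated value is 100000 nM, with an expected range from 50000 nM to 200000 nM.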

Compound 4, half-maximal cytotoxic concentration: > 100000 nM
Compound 4 was reported as a limit; the forecaster's own chance of this, stated with the estimate: 85%; the middle value lies on the limit itself.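

In this assay compound 4 gives > 100000 nM, which is a limit of the assay and not a number. Compound 1 offers no number to set against it, so no step can be read between them. The compounds shown leave open what concentration, if any, would harm these cells.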